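This account rests on a few compounds, and the source may have more. Where it says the series, first, only, none or still open, it means among the compounds named here.

Of the compounds shown here, three sharing one core have been measured in a functional assay on HT-29 cells (Homo sapiens) for antiproliferative activity, read by sulforhodamine B assay, with a stated time of 48 h; a lower number here means a stronger inhibitor, a higher number a weaker inhibitor. Compound 1 `O=C1NCCN1c1ccc(S(=O)(=O)Nc2ccc(F)cc2)cc1` gives 370 nM. Compound 2 `CCCCOc1ccc(NS(=O)(=O)c2ccc(N3CCNC3=O)cc2)cc1` gives 630 nM, and compound 3 `Cc1ccc(C)c(NS(=O)(=O)c2ccc(N3CCNC3=O)cc2)c1` gives 46 nM. Among these three numbers compound 1 stands second highest: the nearest of the others shows a 1.7-fold higher number from compound 1 to compound 2 (0.23 log units; within the scatter), and the furthest shows an 8.0-fold lower number from compound 1 to compound 3 (0.91 log units; beyond the scatter).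

The unmeasured compound 4 `COc1ccc(NS(=O)(=O)c2ccc(N3CCNC3=O)cc2)cc1` differs from compound 1 in a single place: methoxy in place of fluoro on an aromatic carbon. The measured step that bears most directly on this change is the one in which fluoro gave way to butoxy on the same aromatic carbon, which produced a 1.7-fold higher number from compound 1 to compound 2 (0.23 log units; within the scatter). The change leading to compound 3 sits on the sulfonamide nitrogen and concerns a different part of the molecule, so it gives little guidance here. Since exchanging fluoro for butoxy stayed within the scatter, exchanging it for methoxy is expected to behave much the same, with no step beyond the scatter in either direction. For compound 4 the expected step is therefore a 1.2-fold higher number from compound 1 to compound 4 (0.09 log units; within the scatter). The value estimated for compound 4 in this assay is 450 nM, with a range from 180 nM to 1100 nM.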

Compound 4, half-maximal inhibitory concentration: 800 nM
Beside the measured number, compound 4's estimate is 1.8-fold (0.25 log units) below it; the measured number falls inside the stated range.
By their numbers in this assay, from the lowest: compound 3; then compounds 1, 2 and 4 (each within the scatter of the next, the first and the last beyond it).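

In this assay, among the compounds shown here, methoxy in place of fluoro on the aromatic carbon para to a large group gives a 2.2-fold higher number from compound 1 to compound 4 (0.33 log units; beyond the scatter), the first change at this position to pass beyond the scatter, though only modestly. Shortening the chain on the oxygen makes no readable difference, since butoxy and methoxy stand within the scatter of each other with a 1.3-fold higher number from compound 2 to compound 4 (0.10 log units; within the scatter), while butoxy itself could not be told apart from fluoro; the small methoxy step therefore shows a slight loss at most, not a clear trend with chain length. The group on the sulfonamide nitrogen matters far more in the compounds shown, as 4-methoxyphenyl in place of 2,5-dimethylphenyl gives a 17-fold higher number from compound 3 to compound 4 (1.24 log units; beyond the scatter), a large step that dwarfs anything seen so far at the fluoro position.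

Still open, as far as these compounds go, is how an amine, a hydroxyl or a chloro group at this same carbon would compare with fluoro, and whether the 2,5-dimethyl pattern would tolerate any of them. Nothing available here accounts for the size of these steps.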